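Formyl to carbamoyl on a shared coumarin-free chlorobenzyl ether core

This account rests on a few compounds, and the source may have more. Where it says the series, first, only, none or still open, it means among the compounds named here.

Compound 1, `CCOc1cc(=O)oc2cc(OCc3cccc(Cl)c3)ccc12`, gives 115 nM in an assay on isolated protein (strain Sprague-Dawley) for inhibition of Amine oxidase [flavin-containing] B (Rattus norvegicus), read by spectrophotometry, with a stated time of 5 min; on this read-out lower numbers stand for stronger inhibition and higher numbers for weaker inhibition. Compound 2, `CN(C)C(=O)COc1cc(=O)oc2cc(OCc3cccc(Cl)c3)ccc12`, gives 501 nM in this assay. Compound 3, `O=Cc1cc(=O)oc2cc(OCc3cccc(Cl)c3)ccc12`, gives 52.5 nM in this assay.

Compound 3 stands lowest of the three numbers. Its nearest neighbour is compound 1, reached by the step of a 2.2-fold lower number from compound 1 to compound 3 (0.34 log units; beyond the scatter); the furthest is compound 2, reached by the step of a 9.5-fold lower number from compound 2 to compound 3 (0.98 log units; beyond the scatter). Both steps replace a larger oxygen-linked group with the formyl group, and both lower the number, the larger group giving the larger fall.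

Compound 4, `NC(=O)c1cc(=O)oc2cc(OCc3cccc(Cl)c3)ccc12`, is not yet measured. Its difference from compound 3 is amino in place of hydrogen on a carbonyl carbon. For the measured compounds named here, no measured pair shows this exact change. The two steps that bear on it, a 2.2-fold lower number from compound 1 to compound 3 (0.34 log units; beyond the scatter) and a 9.5-fold lower number from compound 2 to compound 3 (0.98 log units; beyond the scatter), only show that groups other than formyl on the shared core have given higher numbers, so a modest rise is expected when the amino group enters the carbonyl carbon, though the step of a 4.4-fold higher number from compound 1 to compound 2 (0.64 log units; beyond the scatter) shows that the size of such a rise varies. Compound 4 is therefore expected to give 95 nM in this assay, within 35 nM to 260 nM, which means an expected step of a 1.8-fold higher number from compound 3 to compound 4 (0.26 log units; within the scatter).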

Compound 4, half-maximal inhibitory concentration: 234 nM
The estimate for compound 4 lay 2.5-fold (0.39 log units) below the measured number; measured number inside the range.
By their numbers in this assay, from the lowest: compound 3; then compound 1; then compound 4; then compound 2.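

On the carbonyl carbon, amino in place of hydrogen gives a 4.5-fold higher number from compound 3 to compound 4 (0.65 log units; beyond the scatter) in this assay, and this is the only step shown in which the carbonyl stays on the aromatic carbon and only the group it carries changes, so keeping the carbonyl there does not by itself preserve the low number of the formyl compound. For the compounds shown here, the carbamoyl group falls among the larger oxygen-linked groups rather than with formyl, with a 2.0-fold higher number from compound 1 to compound 4 (0.31 log units; beyond the scatter) and a 2.1-fold lower number from compound 2 to compound 4 (0.33 log units; beyond the scatter), which leaves formyl as the only one of the four groups at this place whose number lies below that of ethoxy. Nothing measured here accounts for the rise on adding the amino group.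

The compounds shown leave open whether the rise is specific to amino or would also appear with a methyl group on the carbonyl carbon, a hydroxyl giving the carboxylic acid, or methylamino and dimethylamino in place of amino. They also leave open whether the same step would hold if the chlorine on the benzyl ether were replaced by fluorine or a methoxy group.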